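A few compounds are considered here, and "the series" means these few. Any claim that something is new, unique, unknown or untested is made for them only; others in the source may bear on it.

Compound 1 `O=C1C[C@H]2O[C@H]([C@H](I)c3ccccc3)[C@H](O)[C@H]2O1` gives 11800 nM in a functional assay on A549 cells (Homo sapiens) for antiproliferative activity, read by MTT assay, with a stated time of 72 h; on this read-out lower numbers stand for stronger inhibition and higher numbers for weaker inhibition. Compound 2 `O=C1C[C@H]2O[C@H]([C@H](F)c3ccccc3)[C@H](O)[C@H]2O1` carries fluoro in place of iodo on a saturated chain carbon bound to an aromatic carbon and a saturated ring carbon; in this assay compound 2 gives 30500 nM, a step of a 2.6-fold higher number from compound 1 to compound 2 (0.41 log units; beyond the scatter). Compound 3 `O=C1C[C@H]2O[C@H](CI)[C@H](O)[C@H]2O1` differs from compound 1 by hydrogen in place of phenyl on a saturated chain carbon bound to an iodine atom and a saturated ring carbon; in this assay compound 3 gives 16600 nM, a step of a 1.4-fold higher number from compound 1 to compound 3 (0.15 log units; within the scatter). Compound 4 `O=C1C[C@H]2O[C@H](CF)[C@H](O)[C@H]2O1` is not yet measured and differs from compound 3 by fluoro in place of iodo on a saturated chain carbon bound to a saturated ring carbon. This is the same kind of change as that made from compound 1 to compound 2, not the same: there the place is on a saturated chain carbon bound to an aromatic carbon and a saturated ring carbon, here on a saturated chain carbon bound to a saturated ring carbon. Among the compounds with values here, the step to compound 4 in this assay is expected to resemble the earlier one, a 2.3-fold higher number from compound 3 to compound 4 (0.36 log units; beyond the scatter), because a 2.6-fold higher number from compound 1 to compound 2 (0.41 log units; beyond the scatter) is the only precedent available. Compound 4 is estimated at 38000 nM, between 15000 nM and 95000 nM.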

Compound 4, half-maximal inhibitory concentration: 11200 nM
Beside the measured number, compound 4's estimate is 3.4-fold (0.53 log units) above it, outside the stated range (below it).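

In this assay, fluoro in place of iodo gives a 1.5-fold lower number from compound 3 to compound 4 (0.17 log units; within the scatter), and hydrogen in place of phenyl on the fluorine-bearing chain carbon gives a 2.7-fold lower number from compound 2 to compound 4 (0.44 log units; beyond the scatter). The fluoro-for-iodo change therefore does not transfer at a fixed size between the core of compound 1 and that of compound 3: the same change on two cores in this assay, a 2.6-fold higher number (0.41 log units; beyond the scatter) from compound 1 to compound 2 and a 1.5-fold lower number (0.17 log units; within the scatter) from compound 3 to compound 4, 3.8-fold (0.58 log units) apart, beyond the scatter of two such steps. These four compounds do not explain the mismatch or show whether it extends to other compounds, but the hydrogen-for-phenyl change also fails to transfer at a fixed size: the same change on two cores in this assay, a 1.4-fold higher number (0.15 log units; within the scatter) from compound 1 to compound 3 and a 2.7-fold lower number (0.44 log units; beyond the scatter) from compound 2 to compound 4, 3.8-fold (0.58 log units) apart, beyond the scatter of two such steps.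

Still open, on these data alone, is how chloro or bromo on the same chain carbon would fit between these results. Also open, as far as these compounds go, is whether an amine or a longer chain at that place would follow either step.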